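Methyl Added to the Sulfonyl Phenyl of Compound 2

This account rests on a few compounds, and the source may have more. Where it says the series, first, only, none or still open, it means among the compounds named here.

Compound 1 `O=S(=O)(c1ccccc1)c1nc2ccccc2nc1Nc1ccc(F)cc1`: 14200 nM
Compound 2 `O=S(=O)(c1ccccc1)c1nc2ccccc2nc1Nc1ccc(C(F)(F)F)cc1`: 3550 nM

In a functional assay on PC-3 cells (Homo sapiens) for cytotoxicity, read by MTT assay, with a stated time of 72 h (a lower number here means a stronger inhibitor, a higher number a weaker inhibitor), compound 1 gives 14200 nM, while compound 2 gives 3550 nM. Compound 2 therefore stands as the lowest of the two numbers shown, the single measured step being a 4.0-fold lower number from compound 1 to compound 2 (0.60 log units; beyond the scatter), a change on the aniline side of the shared core.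

Compound 3 `Cc1ccc(S(=O)(=O)c2nc3ccccc3nc2Nc2ccc(C(F)(F)F)cc2)cc1` differs from compound 2 by methyl in place of hydrogen on an aromatic carbon. No measured step touches the phenylsulfonyl side of the core, so the change has no direct precedent among these compounds; the step of a 4.0-fold lower number from compound 1 to compound 2 (0.60 log units; beyond the scatter) concerns a different ring and gives little guidance. With nothing to anchor a shift, compound 3 is expected to sit close to compound 2, the expected step being a 1.1-fold lower number from compound 2 to compound 3 (0.05 log units; within the scatter), with no movement beyond the scatter. Compound 3 is thus estimated at 3200 nM, in a range from 1000 nM to 10000 nM.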

Compound 3, half-maximal inhibitory concentration: 2540 nM
Beside the measured number, compound 3's estimate is 1.3-fold (0.10 log units) above it, and the stated range covers the measured number.
By their numbers in this assay, from the lowest: compounds 3 and 2 (each within the scatter of the next); then compound 1.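

The phenylsulfonyl side of the shared core now has its first measured step in this assay and it is a 1.4-fold lower number from compound 2 to compound 3 (0.15 log units; within the scatter) so phenylsulfonyl to (4-methylphenyl)sulfonyl leaves compound 3 and compound 2 within the scatter of each other. This aromatic carbon, para to a large group, therefore takes a methyl with no shift that the assay can separate from repeat variation, unlike the earlier step on the aniline side, which lay beyond the scatter. No supporting measurement bears on this result.

On these data alone, whether an amine, a carboxylic acid or a longer chain at this position would move the number beyond the scatter remains open. Also open, as far as these compounds go, is whether the same methyl would behave alike on compound 1, which carries fluoro in place of trifluoromethyl.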